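The source may hold more compounds than are shown below. What is called first, only, known or untested is meant among the compounds shown, and "the series" means these compounds.

Measured compounds:
compound 1 `Cc1nc(C)c(S(=O)(=O)NC(=O)NC/C=C2\CCCc3cnn(Cc4ccc(Cl)cc4Cl)c32)s1`, 4 nM
compound 2 `O=C(NC/C=C1\CCCc2cnn(Cc3ccc(Cl)cc3Cl)c21)NS(=O)(=O)c1cc(Cl)c(Cl)s1`, 11 nM

In a functional assay on CHO-K1 cells for antagonist activity at prostaglandin E2 receptor EP3 subtype (Homo sapiens), read by TR-FRET and cAMP accumulation, with a stated time of 30 min (on this read-out higher numbers stand for weaker inhibition and lower numbers for stronger inhibition), compound 2 gives the higher of the two numbers, the only other being compound 1, and the one step shown is a 2.8-fold higher number from compound 1 to compound 2 (0.44 log units; beyond the scatter). Compound 3 `O=C(NC/C=C1\CCCc2cnn(Cc3ccc(Cl)cc3Cl)c21)NS(=O)(=O)c1cccs1` differs from compound 2 in one place: thiophen-2-yl in place of 4,5-dichlorothiophen-2-yl on a sulfonyl sulfur. The same position was changed in the step from compound 1 to compound 2, which was modest and beyond the scatter, so a change there is expected to matter, but its direction here is not fixed by that step. Compound 3 is estimated at 20 nM, between 6 nM and 70 nM, a step of a 1.8-fold higher number from compound 2 to compound 3 (0.26 log units; within the scatter) that may well stay within the scatter.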

Compound 3, half-maximal inhibitory concentration: 28 nM
The estimate for compound 3 lay 1.4-fold (0.15 log units) below the measured number, within the range that was stated.
By their numbers in this assay, from the lowest: compound 1; then compound 2; then compound 3.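

In this assay, thiophen-2-yl in place of 4,5-dichlorothiophen-2-yl gives a 2.5-fold higher number from compound 2 to compound 3 (0.41 log units; beyond the scatter), which shows that the two chlorine atoms on this thiophene go with stronger inhibition. Among the three groups on the sulfonyl sulfur, 2,4-dimethyl-1,3-thiazol-5-yl stays the strongest, and the widest gap is a 7.0-fold higher number from compound 1 to compound 3 (0.85 log units; beyond the scatter). Nothing available explains this order. The compounds shown leave open whether a single chlorine on the thiophene would be enough. They also leave open how a phenyl or pyridine ring would compare on the same sulfonyl sulfur.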